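The source may report more compounds than this note shows. Statements on the series, on what has been measured and on what is new or still open speak of the compounds shown alone.

Of the compounds shown here, three with a shared core have been tested so far: compound 1 `CC1=NN(C(=O)c2sc3ccccc3c2Cl)C(=O)/C1=N/Nc1ccccc1`, compound 2 `Clc1ccccc1OCc1nnc2sc(-c3sc4ccccc4c3Cl)nn12` and compound 3 `Cc1ccccc1OCc1nnc(-c2sc3ccccc3c2Cl)o1`. In a functional assay on the whole organism (strain Wistar) for inhibition, with Rattus norvegicus as the target, read by paw edema, with stated times of 1 h and 3 h, at a dose of 10 mg/kg by the oral route (a lower number here means less inhibition, a higher number more inhibition at the dose given (going by the name of the read-out)), compound 1 gives 48.6%. In this assay compound 2 gives 41.9%, and compound 3 gives 33.7%. On the bare numbers compound 2 sits between the other two, yet its gap to compound 1 and its gap to compound 3 both lie within the usual scatter of repeated measurements, so the three compounds cannot be told apart in this assay.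

Compound 4 `Cc1ccc(OCc2nnc3sc(-c4sc5ccccc5c4Cl)nn23)cc1` has not yet been measured. It differs from compound 2 in one place: 4-methylphenyl in place of 2-chlorophenyl on an oxygen on a saturated carbon. Within the data shown here, no pair of measured compounds differing in a single place is available, so there is no measured step to lean on. With the three measured values lying so close together, the step from compound 2 to compound 4 in this assay is expected to be small, estimated at a number 0.1 percentage points higher from compound 2 to compound 4 (within the scatter), which would not go beyond the scatter in either direction. Compound 4 is therefore expected to give about 42%, with a likely range from 28% to 56%.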

Compound 4, a percentage reported as inhibition, in the whole organism at one dose (the size of the read-out at that dose, not a potency): 43.5%
Compound 4: middle estimate off by 1.5 percentage points, on the low side; measured number inside the range.
By their numbers in this assay, from the lowest: compounds 3, 2, 4 and 1 (each within the scatter of the next, the first and the last beyond it).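

In this assay, among these compounds, the change of 2-chlorophenyl to 4-methylphenyl on an oxygen on a saturated carbon gives the first step that can be read at a single place, a number 1.6 percentage points higher from compound 2 to compound 4 (within the scatter), so the two groups cannot be told apart here. This change replaces chlorine with methyl and also moves the group from the 2 to the 4 place on the ring, so any separate contributions of these two differences remain hidden within this one step. No measurement at hand explains the result.

Still open, from the compounds shown here alone, is whether 4-chlorophenyl or plain phenyl would also match these compounds, which would help to separate the two differences. Going by these compounds, it is equally open whether a ring carrying an amine or a carboxylic acid, or a longer chain in place of the saturated carbon, would produce a step beyond the scatter.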